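Piperazinylacetamides on the shared core: methyl to phenyl

The source may hold more compounds than are shown below. What is called first, only, known or untested is meant among the compounds shown, and "the series" means these compounds.

Two numbers exist so far in a functional assay on HT-29 cells (Homo sapiens) for cytotoxicity, read by MTT assay, with a stated time of 24 h, tested at 0.64 ug/mL; on this read-out higher numbers stand for a stronger effect at the one concentration tested and lower numbers for a weaker effect. Compound 2 `CN1CCN(CC(=O)Nc2ccc(-c3nc(-c4ccccc4)c(-c4ccccc4)n3C)cc2)CC1` gives 18.8% in this assay, and compound 1 `Cn1c(-c2ccc(NC(=O)CSc3nc4ccccc4s3)cc2)nc(-c2ccccc2)c1-c1ccccc1` gives 9.8%. For the measured compounds named here, the one measured step, a number 9 percentage points higher from compound 1 to compound 2 (within the scatter), is within the scatter, so the two compounds cannot be ordered against each other; compound 2 simply carries the larger of two figures that do not differ beyond the usual spread.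

Compound 3 `Cn1c(-c2ccc(NC(=O)CN3CCN(c4ccccc4)CC3)cc2)nc(-c2ccccc2)c1-c1ccccc1` is next. It differs from compound 2 by phenyl in place of methyl on an amine nitrogen in a ring. Going by the values given here, no measured step touches this change: the step from compound 1 to compound 2 swaps the whole group on the saturated chain carbon bound to the carbonyl carbon and says nothing about the substituent on the ring nitrogen of the 4-methylpiperazin-1-yl group. Among the compounds with values here, the only step, being within the scatter, gives no reason to expect a change beyond the scatter here either. Compound 3 is therefore expected to read close to compound 2, with a number 0.8 percentage points lower from compound 2 to compound 3 (within the scatter) as the expected step. The estimate for compound 3 is 18%, with a range from 5% to 38%.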

Compound 3, a percentage reported as activity, at one concentration (the size of the read-out at that concentration, not a potency): 17.3%
For compound 3 the middle estimate is 0.7 percentage points above the measured one; the range from low to high includes it.
By their numbers in this assay, from the lowest: compounds 1, 3 and 2 (each within the scatter of the next).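

In this assay, for the compounds shown here, phenyl in place of methyl on the amine nitrogen in the ring gives a number 1.5 percentage points lower from compound 2 to compound 3 (within the scatter), the first reading at this position: 1 heavy atom gives way to 6 heavy atoms and a six-membered aromatic ring of carbon only, and the change stays inside the usual spread of repeated measurements. At the saturated chain carbon bound to a carbonyl carbon, 4-phenylpiperazin-1-yl in place of (1,3-benzothiazol-2-yl)sulfanyl gives a number 7.5 percentage points higher from compound 1 to compound 3 (within the scatter), so this exchange, like the one with 4-methylpiperazin-1-yl, does not separate the compounds and all three remain unordered. Nothing available bears on the reason for these readings.

Still open, from the compounds shown here alone, is whether a plain hydrogen, a benzyl group or an acetyl group on that ring nitrogen, or a longer chain in place of the single saturated chain carbon, would read apart from compound 2 and compound 3. All the readings also stand at one concentration, so they give the size of the effect there and leave open how the compounds would compare in potency.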